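Taking the bromo group off compound 2

This account rests on a few compounds, and the source may have more. Where it says the series, first, only, none or still open, it means among the compounds named here.

Compound 1 `COc1cc2c(cc1OC)C(c1ccc([N+](=O)[O-])cc1)=NN=C(S)C2`: 69.8 umol/kg
Compound 2 `COc1cc2c(cc1OC)C(c1ccc(Br)cc1)=NNC(=O)C2`: 82.5 umol/kg

Both compounds were examined in a functional assay on the whole organism with Mus musculus as the target; on this read-out higher numbers stand for an effect only at larger amounts of compound and lower numbers for an effect already at smaller amounts. In this assay, compound 2 at 82.5 umol/kg stands within the usual scatter of compound 1 at 69.8 umol/kg. Among the compounds with values here, the two structures differ in more than one place, so this pair gives no clean step for any single change.

Compound 3 `COc1cc2c(cc1OC)C(c1ccccc1)=NNC(=O)C2` has not yet been measured. Its structure departs from that of compound 2 in one place only: hydrogen in place of bromo on an aromatic carbon. This is hydrogen in place of bromo on an aromatic carbon. Within the data shown here, no measured pair isolates this change, so the expectation rests on thin evidence. Among the measured compounds shown here, the only guide is that compound 1 at 69.8 umol/kg and compound 2 at 82.5 umol/kg remain close despite their differing structures. No step beyond the scatter is therefore expected in this assay, although a wide margin is needed in both directions. The expected step is a 1.1-fold higher number from compound 2 to compound 3 (0.04 log units; within the scatter). Compound 3 is expected at 90 umol/kg, within an estimated range of 40 umol/kg to 200 umol/kg.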

Compound 3, dose for half-maximal effect: 31.8 umol/kg
Beside the measured number, compound 3's estimate is 2.8-fold (0.45 log units) above it; measured number outside the range, below it.
By their numbers in this assay, from the lowest: compound 3; then compounds 1 and 2 (each within the scatter of the next).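

In this assay, within the data shown here, the change from 4-bromophenyl to phenyl gives the first clean single-change step in this set (a 2.6-fold lower number from compound 2 to compound 3 (0.41 log units; beyond the scatter)), which shows that the bromo group on this aromatic carbon is not neutral here: the compound carrying hydrogen instead shows its effect at smaller amounts of compound. The earlier pair differed in more than one place and so could say nothing about this position alone, whereas here only one bromine atom leaves, a hydrogen enters and the rest of the structure stays the same. Nothing available explains the direction or the size of this step, and it rests on a single pair.

Whether chloro, methoxy, an amine or a carboxylic acid on this same carbon would side with hydrogen or with bromo remains open, so the compounds shown cannot say whether the step is particular to bromine or would follow any group placed there. As far as these compounds go, it is equally open whether the same change would give a step of similar size alongside the other structural differences seen in compound 1.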